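This account rests on a few compounds, and the source may have more. Where it says the series, first, only, none or still open, it means among the compounds named here.

In an assay on isolated protein for inhibition of DNA topoisomerase 1 (Homo sapiens), with a stated time of 30 min, tested at 100 uM (on this read-out higher numbers stand for a stronger effect at the one concentration tested and lower numbers for a weaker effect), compound 1 `COc1cc(OC)cc(-c2cc3ccccc3c(-c3cccc(OC)c3)n2)c1` gives 0%, and compound 2 `COc1ccc(-c2cc3cc(C)ccc3c(-c3cccc(O)c3)n2)cc1OC` gives 1.7%. On these two numbers compound 2 sits alongside compound 1, the two values lying within the usual scatter of each other, so neither can be set above the other. Compound 3 `COc1ccc(-c2cc3cc(C)ccc3c(-c3ccc(O)cc3)n2)cc1OC` differs from compound 2 by 4-hydroxyphenyl in place of 3-hydroxyphenyl on an aromatic carbon. Among the measured compounds shown here, with no step between measured compounds available, the step from compound 2 to compound 3 is expected to be a number 0.7 percentage points lower from compound 2 to compound 3 (within the scatter), nothing beyond the scatter in either direction. Compound 3 is therefore estimated at 1%, with a range from 0% to 10%.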

Compound 3, a percentage reported as inhibition, at one concentration (the size of the read-out at that concentration, not a potency): 0.3%
Compound 3: the middle estimate sits 0.7 percentage points above what was measured, and the stated range covers the measured number.
By their numbers in this assay, from the lowest: compounds 1, 3 and 2 (each within the scatter of the next).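

In this assay, 4-hydroxyphenyl in place of 3-hydroxyphenyl on the aromatic carbon next to the ring nitrogen gives a number 1.4 percentage points lower from compound 2 to compound 3 (within the scatter). Among the compounds shown here, this is the first comparison here of compounds differing in one place, and it shows that exchanging these two hydroxyphenyl groups leaves the read-out within the scatter. No further measurement bears on this result. The compounds shown leave open whether an aminophenyl group or a benzoic acid at this place, or a longer chain ending in an amine, would change the read-out.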